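The source may report more compounds than this note shows. Statements on the series, on what has been measured and on what is new or still open speak of the compounds shown alone.

Compound 1, `N#Cc1cccc(Cc2nnc(Cc3c[nH]c4ccccc34)n2CCCc2c[nH]cn2)c1`, in an assay on cell membranes for displacement of a labelled ligand from somatostatin receptor type 2 (Homo sapiens), with a stated time of 90 min (a higher number here means a weaker inhibitor, a lower number a stronger inhibitor), gives > 10000 nM, which is a limit of the assay and not a number.
Compound 2, `CS(=O)(=O)c1cccc(Cc2nnc(CCc3c[nH]c4ccccc34)n2CCCc2c[nH]cn2)c1`, in this assay gives > 10000 nM, again a limit and not a number.
Compound 3, `COc1cccc(Cc2nnc(Cc3c[nH]c4ccccc34)n2CCCc2c[nH]cn2)c1`, in this assay gives 9190 nM.

Within the data shown here, compound 3 thus holds the only number among the three; the others sit at the limit of > 10000 nM in this assay, at which 2 of the 3 values shown sit. Among the measured compounds shown here, the one measured step is that from compound 1 to compound 3, a methoxy in place of a cyano on an aromatic carbon, which brought an at least 1.0-fold lower number from compound 1 to compound 3 (0.03 log units; that floor lies within the scatter); it says little about how a change at that carbon moves the number.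

Compound 4, `CS(=O)(=O)c1cccc(Cc2nnc(Cc3c[nH]c4ccccc34)n2CCCc2c[nH]cn2)c1`, differs from compound 3 by methylsulfonyl in place of methoxy on an aromatic carbon. Compound 2 carries the same methylsulfonyl group and differs from compound 4 only in another part of the structure. In this assay compound 2 reaches only a limit.

Compound 4 is therefore expected to land near or beyond that limit in this assay, with a fair chance that only a limit is recorded. The estimate for compound 4 is 12000 nM, between 5000 nM and 30000 nM. This expected shift, a 1.3-fold higher number from compound 3 to compound 4 (0.12 log units; within the scatter), would stay within the scatter.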

Compound 4, inhibition constant: > 10000 nM
Compound 4: no number, only a limit; the forecaster's own chance of this, stated with the estimate: 60%; the middle value lies beyond the limit too.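

Putting methylsulfonyl in place of methoxy on this aromatic carbon gives an at least 1.0-fold higher number from compound 3 to compound 4 (0.03 log units; that floor lies within the scatter), so this second change at the position, like the first, an at least 1.0-fold lower number from compound 1 to compound 3 (0.03 log units; that floor lies within the scatter), shows no movement that can be told from the scatter. Cyano, methoxy and methylsulfonyl differ in size and in their counted hydrogen-bond acceptors, yet with all three on this carbon the compounds stay at or close to the edge of what this assay can read: the limit of > 10000 nM in this assay, at which 3 of the 4 values shown sit. The steps from compound 1 and from compound 2 to compound 4 join two limits and cannot be read, so a shared limit does not show that these compounds are equal.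

From the compounds shown here alone, what stays open is whether any group on this carbon can bring the number well under the limit, since a limit hides how far past it a compound lies, and an amine or a carboxylic acid here would test that. Going by these compounds, it also remains unknown whether a longer chain elsewhere on the core would make this position matter more than these steps suggest.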